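The compounds below may be only part of what the source reports. "The series", "measured", "known", "first", "only" and "open" are said of these compounds alone.

Measured in an ADME assay on WI-38 cells (Homo sapiens) for cytotoxicity, read by MTT assay, with a stated time of 72 h; a lower number here means a stronger inhibitor, a higher number a weaker inhibitor:
- compound 1 `O=C(CCc1cccc2c1B(O)OC2)Nc1cccc(I)c1`: 71000 nM
- compound 2 `O=C(CCc1cccc2c1B(O)OC2)Nc1cccc(-c2ccc(Cl)cc2)c1`: 9800 nM

Compound 2 has the lower number of the pair. Compound 3 `O=C(CCc1cccc2c1B(O)OC2)Nc1cccc(-c2cccc(C(F)(F)F)c2)c1` has not been measured yet. Its difference from compound 2 is this: 3-(trifluoromethyl)phenyl in place of 4-chlorophenyl on an aromatic carbon. For the measured compounds named here, only one measured step bears on this change: a 7.2-fold lower number from compound 1 to compound 2 (0.86 log units; beyond the scatter), a modest step beyond the scatter that put 4-chlorophenyl in place of iodo. The present change instead swaps one group with a six-membered aromatic ring of carbon only for another, so no step beyond the scatter is expected in this assay. The expected step is a 1.2-fold lower number from compound 2 to compound 3 (0.06 log units; within the scatter). Compound 3 is estimated at 8500 nM, within a range of 3500 nM to 20000 nM.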

Compound 3, half-maximal inhibitory concentration: 23000 nM
Estimate against measurement, compound 3: 2.7-fold (0.43 log units) below, and the stated range ends below it.
By their numbers in this assay, from the lowest: compound 2; then compound 3; then compound 1.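

In this assay the two aryl groups at this place are not interchangeable: the swap gives a 2.3-fold higher number from compound 2 to compound 3 (0.37 log units; beyond the scatter) even though each group is one six-membered aromatic ring of carbon only. The drop from iodo holds for the second aryl group too, with a 3.1-fold lower number from compound 1 to compound 3 (0.49 log units; beyond the scatter) as its step. Nothing measured here accounts for the gap between the two aryl groups.

These two groups differ both in substituent and in where it sits on the ring, so neither difference can be credited alone. As far as these compounds go, how unsubstituted phenyl, or a ring carrying an amine or a carboxylic acid, would read at this place remains open.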